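Fluorine on the Outer Ring, Tested on Two Cores

The source may report more compounds than this note shows. Statements on the series, on what has been measured and on what is new or still open speak of the compounds shown alone.

Measured compounds:
compound 1, `C/N=C(/S)[C@@]1(c2cccnc2)CCCC[C@@H]1CCOC(=O)c1ccccc1`, gives 30 nM
compound 2, `C/N=C(/S)[C@@]1(c2cccnc2)CCCC[C@@H]1CCOC(=O)c1ccc(F)cc1`, gives 100 nM
compound 3, `C/N=C(/S)[C@@]1(c2cccnc2)CCCC[C@@H]1C/C=C/c1ccccc1`, gives 100 nM

All three numbers come from a functional assay (aorta) with Rattus norvegicus as the target; a higher number here means a weaker inhibitor, a lower number a stronger inhibitor. Compound 1 and compound 2 share one core and differ in a single place: fluoro in place of hydrogen on an aromatic carbon. This change produced a 3.3-fold higher number from compound 1 to compound 2 (0.52 log units; beyond the scatter), so the fluorinated compound 2 is the weaker inhibitor of the pair.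

Compound 3 carries a different core; how the two cores differ is not broken down here. In this assay compound 3 stands level with compound 2 at the digits given, and sits a clear step above compound 1.

The unmeasured compound 4, `C/N=C(/S)[C@@]1(c2cccnc2)CCCC[C@@H]1C/C=C/c1ccc(F)cc1`, is made from compound 3 by the same change that turned compound 1 into compound 2: fluoro in place of hydrogen on an aromatic carbon. The place of the new fluorine reads identically in both pairs, so the change is the same kind of change, only applied to another core.

For the measured compounds named here, because the single measured example of this change gave a 3.3-fold higher number from compound 1 to compound 2 (0.52 log units; beyond the scatter), the expectation is that compound 4 will also show a weaker result than compound 3, estimated as a 3.0-fold higher number from compound 3 to compound 4 (0.48 log units; beyond the scatter). For compound 4 the estimated value in this assay is 300 nM, expected to lie between 120 nM and 800 nM. This rests on a single precedent and on a core whose relation to the first is not resolved, so the range is kept wide.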

Compound 4, concentration for 90% inhibition: 10 nM
Beside the measured number, compound 4's estimate is 30-fold (1.48 log units) above it; the whole stated range lies above it.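

In this assay, the change from phenyl to 4-fluorophenyl on the second core gave a 10-fold lower number from compound 3 to compound 4 (1.00 log units; beyond the scatter), so here the added fluoro goes with a stronger inhibitor, not a weaker one. The same small change therefore moved the number in opposite directions on the two cores, and the gap between the two results is too large to put down to ordinary variation between repeated measurements: the same change on two cores in this assay, a 3.3-fold higher number (0.52 log units; beyond the scatter) from compound 1 to compound 2 and a 10-fold lower number (1.00 log units; beyond the scatter) from compound 3 to compound 4, 33-fold (1.52 log units) apart, beyond the scatter of two such steps This shows that, in this series, the result of adding this fluoro on one core cannot simply be carried over to another, since the outcome depends on the rest of the molecule; it does not show which part of the molecule is responsible or why, and two pairs of compounds are too few to establish a general rule.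

From the compounds shown here alone, it remains open whether other groups on the same aromatic carbon, such as a chlorine atom or a methoxy group, would also pull the two cores in opposite directions. Going by these compounds, it also remains open whether a third core, with a different chain leading to the outer ring, would follow compound 1 and compound 2 or compound 3 and compound 4.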